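The compounds below may be only part of what the source reports. "The series", "measured", "known", "first", "only" and "open" are said of these compounds alone.

Compound 2 `Nc1nc(OCc2cccc(Cl)c2)c2nn[nH]c2n1` was examined in an assay on isolated protein for inhibition of Myeloperoxidase (Homo sapiens), read by fluorescence, with stated times of 10 min, 30 s and 5 min (on this read-out higher numbers stand for weaker inhibition and lower numbers for stronger inhibition), where compound 2 gives 200 nM. Compound 1 `Nc1ccc(Oc2cc(Cl)c(Cl)cc2Cl)cn1` in this assay gives 360 nM, and the two numbers lie within the scatter of each other, so neither compound is set apart from the other. Compound 3 `Nc1nc(OCc2cccc(OC(F)F)c2)c2nn[nH]c2n1` differs from compound 2 by difluoromethoxy in place of chloro on an aromatic carbon. Within the data shown here, no measured pair shows this change, so no direction can be read from the data. The step is expected to be a 1.3-fold higher number from compound 2 to compound 3 (0.10 log units; within the scatter), within the scatter. Compound 3 is estimated at 250 nM, ranging from 80 nM to 800 nM.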

Compound 3, half-maximal inhibitory concentration: 200 nM
Estimate against measurement, compound 3: 1.3-fold (0.10 log units) above; measured number inside the range.
By their numbers in this assay, from the lowest: compounds 2, 3 and 1 (each within the scatter of the next).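

In this assay, difluoromethoxy in place of chloro on this aromatic carbon, meta to a large group, gives no change at the digits printed from compound 2 to compound 3 (within the scatter). Among these compounds, this is the first comparison that differs in one place, and it shows that the position takes difluoromethoxy, with more heavy atoms and a hydrogen-bond acceptor, without a shift beyond the scatter. Nothing available explains this result. As far as these compounds go, whether an amine, a carboxylic acid or a longer chain on this carbon would also leave the number within the scatter stays open. So does the effect of hydrogen there in place of chloro.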